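The source may hold more compounds than are shown below. What is called first, only, known or untested is meant among the compounds shown, and "the series" means these compounds.

Of the compounds shown here, two have so far been measured in a functional assay on C6 cells (Rattus norvegicus) for cytotoxicity, read by MTT assay, with a stated time of 24 h, tested at 200 ug/mL; on this read-out lower numbers stand for a stronger effect and higher numbers for a weaker effect at the one concentration tested. Compound 1 `Cc1nnc(SCC(=O)N/N=c2/scc(-c3ccc(Cl)cc3)n2-c2ccccc2)s1` gives 29% in this assay, and compound 2 `O=C(CSc1ncccn1)N/N=c1/scc(-c2ccc(Cl)cc2)n1-c1ccccc1` gives 39.7%, the higher of the two numbers, the gap being beyond the scatter. For the measured compounds named here, the single measured step, a number 10.7 percentage points higher from compound 1 to compound 2 (beyond the scatter), is a modest one and concerns the group on a sulfur only. Compound 3 `O=C(CSc1ncccn1)N/N=c1/scc(-c2ccc(F)cc2)n1-c1ccccc1` differs from compound 2 at another place: fluoro in place of chloro on an aromatic carbon. Going by the values given here, no measured step touches this place, so the data give no ground for a shift in either direction in this assay, and a step within the scatter is the plainest expectation. Compound 3 is therefore expected to give about 40% in this assay, with a range from 26% to 54%. For compound 3 the expected step is a number 0.3 percentage points higher from compound 2 to compound 3 (within the scatter), one not beyond the scatter.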

Compound 3, a percentage reported as activity, at one concentration (the size of the read-out at that concentration, not a potency): 32.2%
Estimate against measurement, compound 3: 7.8 percentage points above, within the range that was stated.
By their numbers in this assay, from the lowest: compounds 1, 3 and 2 (each within the scatter of the next, the first and the last beyond it).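

In this assay, for the compounds shown here, this is the first reading at this position, and it gives a number 7.5 percentage points lower from compound 2 to compound 3 (within the scatter). Fluoro in place of chloro on this aromatic carbon, para to a large group, therefore does not separate the two compounds beyond the scatter, whereas the only earlier step, at the group on a sulfur, did go beyond it. Nothing at hand explains the result in terms of either halogen.

From the compounds shown here alone, whether a different kind of group at this place, such as an amine, a methoxy group or a carboxylic acid, would shift the number beyond the scatter remains open. Also open, going by these compounds, is whether the same exchange would read alike with 5-methyl-1,3,4-thiadiazol-2-yl on the sulfur in place of pyrimidin-2-yl.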